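The compounds below may be only part of what the source reports. "The series", "measured", "known", "first", "only" and "open" are said of these compounds alone.

Compound 1 `CCN1CCN(c2cc(C)c3cc(NC(=O)c4ccccc4F)ccc3n2)CC1` is the weakest of the three measured compounds in a functional assay on SK-BR-3 cells (Homo sapiens) for antiproliferative activity, read by MTT assay, with a stated time of 72 h (on this read-out lower numbers stand for stronger inhibition and higher numbers for weaker inhibition), where compound 1 gives 38100 nM. Compound 2 `Cc1cc(NCCN2CCN(C)CC2)nc2ccc(NC(=O)c3ccc(Cl)c(Cl)c3)cc12` gives 2690 nM in this assay, and compound 3 `CCN(CC)CCNc1cc(C)c2cc(NC(=O)c3ccc(Cl)c(Cl)c3)ccc2n1` gives 3710 nM, both lower than compound 1 by more than the scatter; between them, a 1.4-fold higher number from compound 2 to compound 3 (0.14 log units; within the scatter), so the amine tail is not decisive here. Compound 4 `CCN1CCN(c2cc(C)c3cc(NC(=O)c4cccc(F)c4)ccc3n2)CC1` has not yet been measured. It differs from compound 1 in one place: 3-fluorophenyl in place of 2-fluorophenyl on a carbonyl carbon. Going by the values given here, no measured pair shows the effect of moving the fluorine around the phenyl ring on the carbonyl carbon; compounds 2 and 3 carry a different substituted aryl and a different linker to the core, so they offer no single-change comparison. With nothing in the data pointing either way, compound 4 is expected to stay close to compound 1, with a 1.3-fold lower number from compound 1 to compound 4 (0.10 log units; within the scatter) lying within the scatter. The estimate for compound 4 in this assay is therefore 30000 nM, with a range from 9000 nM to 100000 nM.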

Compound 4, half-maximal inhibitory concentration: 24900 nM
The estimate for compound 4 lay 1.2-fold (0.08 log units) above the measured number, within the range that was stated.
By their numbers in this assay, from the lowest: compounds 2 and 3 (each within the scatter of the next); then compounds 4 and 1 (each within the scatter of the next).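

In this assay, going by these compounds alone, the change to 3-fluorophenyl in place of 2-fluorophenyl on a carbonyl carbon gives a 1.5-fold lower number from compound 1 to compound 4 (0.18 log units; within the scatter) and is the first single-change reading at this place, one that compounds 2 and 3 could not supply. With the same atoms joined differently, the two fluorophenyl groups on this carbonyl carbon are not told apart by this read-out, at least on the core of compound 1. No measured information is available to explain this result. Going by these compounds, whether an unsubstituted phenyl or a methoxyphenyl on the same carbonyl carbon would also stay within the scatter of compound 1 remains open. Compounds 2 and 3 differ from compound 1 and compound 4 in more than one place, so the contributions of the 3,4-dichlorophenyl group and of the amine-bearing chain cannot be separated.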